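The compounds below may be only part of what the source reports. "The series", "measured", "known", "first", "only" and "open" are said of these compounds alone.

The series shares the core of compound 1 `COc1ccc(Nc2cc(C)nc(SCc3nc4ccccc4[nH]3)n2)cc1`, varied at the aromatic nitrogen that carries the anilino or alkylamino group. In a functional assay on MCF7 cells (Homo sapiens) for cytotoxicity, read by MTT assay, with a stated time of 72 h (on this read-out lower numbers stand for stronger inhibition and higher numbers for weaker inhibition), compound 1 gives 61100 nM. Compound 3 `Cc1cc(Nc2ccc(Br)cc2)nc(SCc2nc3ccccc3[nH]2)n1` gives 38000 nM in this assay. Compound 2 `Cc1cc(NC(C)C)nc(SCc2nc3ccccc3[nH]2)n1` returns only a limit in this assay, > 100000 nM. Compound 2 thus sits at the limit of > 100000 nM in this assay, at which 1 of the 3 values shown sits, so its place among the measured values is known only as a bound. The steps around it read an at least 1.6-fold higher number from compound 1 to compound 2 (0.21 log units; that floor lies within the scatter) and an at least 2.6-fold lower number from compound 2 to compound 3 (0.42 log units; beyond the scatter), each an exchange of isopropyl for an aryl group, while a 1.6-fold lower number from compound 1 to compound 3 (0.21 log units; within the scatter) stays within the scatter.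

Compound 4 `COc1ccccc1Nc1cc(C)nc(SCc2nc3ccccc3[nH]2)n1` follows the same direction: 2-methoxyphenyl in place of isopropyl on a nitrogen on an aromatic ring. Both measured aryl-for-isopropyl steps, an at least 1.6-fold higher number from compound 1 to compound 2 (0.21 log units; that floor lies within the scatter) and an at least 2.6-fold lower number from compound 2 to compound 3 (0.42 log units; beyond the scatter), show the aryl compound giving the lower number, the second beyond the scatter. For compound 4 a lower number than the limit of compound 2 is therefore expected, with an at least 1.8-fold lower number from compound 2 to compound 4 (0.25 log units; that floor lies within the scatter). Compound 4 is estimated at 55000 nM, with a range from 20000 nM to 150000 nM.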

Compound 4, half-maximal inhibitory concentration: > 100000 nM
Compound 4: only a limit was reported; the forecaster's own chance of this, stated with the estimate: 25%; at least 1.8-fold (0.25 log units) between middle value and limit.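

Compound 4 returns only a limit, and the step between compound 2 and compound 4 cannot be read, as both stand at that limit: the limit of > 100000 nM in this assay, at which 2 of the 4 values shown sit.

An aryl group on the nitrogen is thus not enough on its own to give a lower number, as 2-methoxyphenyl in place of 4-bromophenyl gives an at least 2.6-fold higher number from compound 3 to compound 4 (0.42 log units; beyond the scatter), and 2-methoxyphenyl in place of 4-methoxyphenyl gives an at least 1.6-fold higher number from compound 1 to compound 4 (0.21 log units; that floor lies within the scatter). Only the first of these is beyond the scatter, so the aryl groups at this position do not all read alike, while the two methoxyphenyl groups remain unseparated.

Still open, going by these compounds, is whether any group on this nitrogen gives a number clearly lower than those of compound 1 and compound 3. Also open, on these data alone, is how a cyclohexyl group or a longer chain such as n-butyl would read there in this assay.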